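Series notes: the step from compound 3 to compound 4

The source may report more compounds than this note shows. Statements on the series, on what has been measured and on what is new or still open speak of the compounds shown alone.

Compound 3 `c1coc(CNCCCNc2ccnc3cc(CC4CCCCC4)ccc23)c1` gives 9.47 in a physicochemical assay for acid dissociation. Its two measured neighbours carry a different group on the same aromatic carbon of the shared core: compound 1 `CC(C)CCc1ccc2c(NCCCNCc3ccco3)ccnc2c1` gives 9.47 in this assay, and compound 2 `Clc1ccc(Oc2ccc3c(NCCCNCc4ccco4)ccnc3c2)cc1` gives 9.28. The three values cannot be told apart: no change at the digits printed from compound 1 to compound 3 (within the scatter), a number 0.19 log units lower from compound 1 to compound 2 (within the scatter), and a number 0.19 log units higher from compound 2 to compound 3 (within the scatter). Compound 3 thus sits with compound 1 and compound 2 in a single band, and no order among the three can be claimed.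

Compound 4 `c1coc(CNCCCNc2ccnc3cc(-c4cccc5ccccc45)ccc23)c1` is the next member. The change is naphthalen-1-yl in place of cyclohexylmethyl on an aromatic carbon. All three measured steps bear on it, since each also exchanges the group on that aromatic carbon, replacing saturated chains, a cyclohexylmethyl and an aryl ether for one another, and each stays within the scatter. Among the compounds with values here, on that basis the exchange of cyclohexylmethyl for naphthalen-1-yl is expected to produce no step in this assay beyond the scatter, with a number 0.07 log units lower from compound 3 to compound 4 (within the scatter) as the expected shift. Compound 4 is therefore estimated at 9.4, in the range 9 to 9.8.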

Compound 4, acid dissociation constant: 9.47
Estimate against measurement, compound 4: 0.07 log units below; the measured number falls inside the stated range.
By their numbers in this assay, from the lowest: compounds 2, 1, 3 and 4 (each within the scatter of the next).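

In this assay, naphthalen-1-yl brings two six-membered aromatic rings of carbon only to the aromatic carbon that earlier held cyclohexylmethyl, and the exchange gives no change at the digits printed from compound 3 to compound 4 (within the scatter) without moving the number out of the band. The same holds against the other two groups at this position, with no change at the digits printed from compound 1 to compound 4 (within the scatter) for the exchange with isopentyl and a number 0.19 log units higher from compound 2 to compound 4 (within the scatter) for the exchange with 4-chlorophenoxy, so the four compounds now form one band in which no order can be claimed, and the range of groups exchanged without a step beyond the scatter extends to a fused aromatic group of 10 heavy atoms. No measurement at hand bears on why the number holds across these exchanges.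

Whether the band survives an amine or a carboxylic acid on the same aromatic carbon stays open, since every group shown there is built from carbon alone or, in 4-chlorophenoxy, from an aryl ether with chlorine. All four compounds also share one side chain on the core, so what a longer chain there would do to this number is equally unknown.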